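A Methyl Added to a Diamine Showing No Inhibition

A few compounds are considered here, and "the series" means these few. Any claim that something is new, unique, unknown or untested is made for them only; others in the source may bear on it.

Measured compounds in an assay for inhibition of Ornithine decarboxylase (Rattus norvegicus); on this read-out lower numbers stand for stronger inhibition and higher numbers for weaker inhibition:
compound 1, structure `CC(C)(CN)C(C)(CN)C(=O)O` — a limit of the assay, > 11000000 nM
compound 2, structure `CC(CN)C(C)(C)CN` — a limit of the assay, > 10500000 nM

Both measured compounds give only a limit in this assay, so no number stands for either of them. Compound 2 therefore stands at the limit of the assay, and the other value shown is also a limit. Going by the values given here, the single step between the measured compounds, a step that the two limits leave unreadable from compound 1 to compound 2, cannot be read because its two ends sit at the limit of > 10500000 nM in this assay, at which 1 of the 2 values shown sits, and (the limit of > 11000000 nM in this assay, at which 1 of the 2 values shown sits).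

Compound 3 has the structure `CC(C)(CN)C(C)(C)CN` and differs from compound 2 by methyl in place of hydrogen on a saturated chain carbon bound to three saturated chain carbons. No measured step bears on this change, and the one step shown has no readable size, so nothing in the data sets a direction for it. With compound 2 at a limit, the expected step is a step that the limit leaves unreadable from compound 2 to compound 3, not beyond the scatter. In this assay compound 3 is therefore estimated at 15000000 nM, with a range from 3000000 nM to 60000000 nM, and it is expected most likely to be reported again only as a limit.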

Compound 3, inhibition constant: > 11000000 nM
Compound 3: no number, only a limit; the forecaster's own chance of this, stated with the estimate: 85%; the middle value does not contradict the limit.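

In this assay compound 3 gives > 11000000 nM, which is a limit of the assay and not a number. Going by these compounds alone, neither its step from compound 1 nor its step from compound 2 can be read, so this result adds no new step: the limit of > 11000000 nM in this assay, at which 2 of the 3 values shown sit. The compounds shown leave open which change to these structures, if any, would give a measurable inhibition.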